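A few compounds are considered here, and "the series" means these few. Any claim that something is new, unique, unknown or untested is made for them only; others in the source may bear on it.

Measured compounds on the shared core:

compound 1 `COc1ccc2c(c1)C(n1ccccc1=O)=CC(C)(C)O2`: 5.99
compound 2 `CC1(C)C=C(n2ccccc2=O)c2cc(C(=O)c3ccccc3F)ccc2O1`: 6.34
compound 3 `Cc1ccccc1C(=O)c1ccc2c(c1)C(n1ccccc1=O)=CC(C)(C)O2`: 6.25

Compound 1 carries the lowest of the three numbers in a functional assay (trachea) with Rattus norvegicus as the target; on this read-out lower numbers stand for lower potency and higher numbers for higher potency (the scale is a negative logarithm). Its nearest neighbour is compound 3, a number 0.26 log units higher from compound 1 to compound 3 (within the scatter); the larger gap is to compound 2, a number 0.35 log units higher from compound 1 to compound 2 (beyond the scatter). Between the two carbonyl compounds the gap is small, a number 0.09 log units lower from compound 2 to compound 3 (within the scatter).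

Compound 4 `CC1(C)C=C(n2ccccc2=O)c2cc(OS(=O)(=O)F)ccc2O1` is not yet measured in this assay. It differs from compound 1 as follows: fluorosulfonyl in place of methyl on an oxygen on an aromatic ring. Within the data shown here, no measured step touches the oxygen on the aromatic ring in this way; both known steps from compound 1 replace the whole methoxy by an aryl carbonyl, and each gave at most a modest rise. Among the measured compounds shown here, the only guide is therefore that changes at this position of the core have so far moved this assay little. Going from methyl to fluorosulfonyl on that oxygen, no step beyond the scatter is expected, in either direction; the expected step is a number 0.11 log units higher from compound 1 to compound 4 (within the scatter), with wide uncertainty. For compound 4 the estimate in this assay is 6.1, within a range of 5.5 to 6.7.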

Compound 4, logarithm of the reciprocal of the active concentration, log(1/C): 7.22
Compound 4: middle estimate off by 1.12 log units, on the low side; measured number outside the range, above it.
By their numbers in this assay, from the lowest: compounds 1, 3 and 2 (each within the scatter of the next, the first and the last beyond it); then compound 4.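

In this assay the oxygen on the aromatic ring turns out to be a place where the group carried can move the number a long way: fluorosulfonyl in place of methyl gives a number 1.23 log units higher from compound 1 to compound 4 (beyond the scatter), whereas the two aryl carbonyl replacements of the whole methoxy gave modest rises at most. The (fluorosulfonyl)oxy group also outruns both carbonyl compounds, with a number 0.97 log units higher from compound 3 to compound 4 (beyond the scatter) and a number 0.88 log units higher from compound 2 to compound 4 (beyond the scatter), so compound 4 stands beyond the scatter of all three earlier compounds. Nothing available explains this rise. Still open, going by these compounds, is whether the gain needs the fluorine or the sulfonyl alone would carry it, which a methylsulfonyl or trifluoromethylsulfonyl group on the same oxygen would test. Also open, on these data alone, is whether a sulfonamide on that aromatic carbon would keep the gain.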